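Step from compound 2 to compound 3 in cytotoxicity

A few compounds are considered here, and "the series" means these few. Any claim that something is new, unique, unknown or untested is made for them only; others in the source may bear on it.

Compounds measured so far:
compound 1 `COc1cc2cc(C#N)ccc2c(OC)c1Oc1cc(NC2CCCC2)nc(Nc2ccc(C#N)cc2)n1` gives > 125000 nM as a limit
compound 2 `COc1cc2cc(C#N)ccc2c(OC)c1Oc1cc(NCC2CCOCC2)nc(Nc2ccc(C#N)cc2)n1` gives > 125000 nM as a limit

Both readings come from an ADME assay on MT4 cells (Homo sapiens) for cytotoxicity, read by MTT assay, with a stated time of 5 days (a higher number here means that more compound is tolerated, a lower number that less compound is tolerated), and neither is a number. Compound 2 thus stands only at a limit. Compound 3 `COc1cc2cc(C#N)ccc2c(OC)c1Oc1cc(NCC(O)CO)nc(Nc2ccc(C#N)cc2)n1` differs from compound 2 as follows: 1,2-dihydroxyethyl in place of oxan-4-yl on a saturated chain carbon bound to a nitrogen on an aromatic ring so that (oxan-4-yl)methyl gives way to 2,3-dihydroxypropyl. Within the data shown here, the one measured step bears on this change but offers no size: a step that the two limits leave unreadable from compound 1 to compound 2 is all it gives. The series otherwise shows only this: the limit of > 125000 nM in this assay, at which 2 of the 2 values shown sit, and nothing more. The expectation rests on compound 2 and its limit of > 125000 nM alone. No step beyond the scatter is expected in this assay and the expected step reads a number no higher from compound 2 to compound 3 (the limit leaves the size open) for now. The estimate for compound 3 is 125000 nM with an expected range of 50000 nM to 250000 nM in this reading.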

Compound 3, half-maximal cytotoxic concentration: 29500 nM
Compound 3: the middle estimate sits 4.2-fold (0.63 log units) above what was measured, and the stated range ends above it.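

In this assay, the group at this place on the nitrogen now shows a readable effect: 1,2-dihydroxyethyl in place of oxan-4-yl gives an at least 4.2-fold lower number from compound 2 to compound 3 (0.62 log units; beyond the scatter), and 2,3-dihydroxypropyl in place of cyclopentyl gives an at least 4.2-fold lower number from compound 1 to compound 3 (0.62 log units; beyond the scatter). The step between compound 1 and compound 2 cannot be read, so the earlier pair showed no such effect. Compound 3 alone gives a number here, and the other two stay at a limit: the limit of > 125000 nM in this assay, at which 2 of the 3 values shown sit.

The change to compound 3 removes the ring and brings in hydrogen-bond donors together, so the compounds shown cannot separate these two differences. From the compounds shown here alone, a plain propyl chain and a propyl chain carrying a single hydroxyl remain open as the groups that would tell them apart.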